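Adding a Methoxybenzyl Group to a Small Amidine Scaffold

The source may hold more compounds than are shown below. What is called first, only, known or untested is meant among the compounds shown, and "the series" means these compounds.

This piece concerns a small set of amidine-bearing compounds tested in a functional assay on PC-3 cells (Homo sapiens) for cytotoxicity, read by MTT assay, with a stated time of 72 h; on this read-out lower numbers stand for stronger inhibition and higher numbers for weaker inhibition. Going by the values given here, only one number exists so far: compound 1 `COc1ccc(Cn2cc3cc(C(=N)Nc4ccc(N5CCN(C)CC5)cc4)ncc3n2)cc1`, which carries a 4-methoxybenzyl group on the core and a methylpiperazinyl-substituted aniline at the amidine, gives 9900 nM in this assay. Compound 2 `Cn1cc2cc(C(=N)Nc3ccccc3)ncc2n1`, the simpler analogue with a bare methyl on the ring nitrogen and an unsubstituted aniline, is recorded in this assay as "not determined" (no result reported), so it stands nowhere on the numbers and offers no anchor of its own.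

The change under consideration leads from compound 2 to compound 3 `COc1ccc(Cn2cc3cc(C(=N)Nc4ccccc4)ncc3n2)cc1`: 4-methoxyphenyl in place of hydrogen on a saturated chain carbon bound to an aromatic nitrogen. Among the compounds with values here, no pair of measured compounds captures this exact change, so the size of the step cannot be read from the data. Whatever compound 3 shows must be judged against compound 1 alone, which shares the 4-methoxybenzyl group but not the aniline substituent. The expectation is that compound 3 lands in a similar, weakly active region, with an estimated value of 15000 nM and a likely range from 3000 nM to 60000 nM, with a real chance that only a limit is reported.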

Compound 3, half-maximal inhibitory concentration: 2040 nM
The estimate for compound 3 lay 7.4-fold (0.87 log units) above the measured number; measured number below the stated range.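

In this assay hydrogen in place of 4-methylpiperazin-1-yl on an aromatic carbon gives a 4.9-fold lower number from compound 1 to compound 3 (0.69 log units; beyond the scatter) and thus shows the first measured effect of a change on this scaffold: with the 4-methoxybenzyl group held constant, the aniline without the 4-methylpiperazin-1-yl group is the stronger of the two. The change from methyl to 4-methoxybenzyl itself cannot be read, as compound 2 has no number, so compound 3 says nothing on whether the 4-methoxyphenyl group raises, lowers or leaves unchanged the activity of the methyl compound. No measurement shown here offers an explanation for the difference between compound 1 and compound 3.

As far as these compounds go, it remains open how an unsubstituted phenyl or a carboxylic acid, in place of 4-methoxyphenyl on a saturated chain carbon bound to an aromatic nitrogen, would compare with compound 3. From the compounds shown here alone, it is equally open whether a smaller amine such as dimethylamino, in place of hydrogen on the aromatic carbon where compound 1 carries 4-methylpiperazin-1-yl, would read like compound 3 or like compound 1.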